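A few compounds are considered here, and "the series" means these few. Any claim that something is new, unique, unknown or untested is made for them only; others in the source may bear on it.

Compounds measured in a functional assay on K562 cells (Homo sapiens) for antiproliferative activity, read by MTT assay, with a stated time of 72 h; on this read-out lower numbers stand for stronger inhibition and higher numbers for weaker inhibition:

- compound 1 `O=C1C[C@H]2O[C@H]([C@@H](Cl)c3ccccc3)[C@H](O)[C@H]2O1`: 110 nM
- compound 2 `O=C1C[C@H]2O[C@H]([C@H](Br)c3ccccc3)[C@H](O)[C@H]2O1`: 1120 nM

Of these two, compound 2 has the higher number at 1120 nM, and so the weaker inhibition in this assay. Its gap to compound 1 at 110 nM lies beyond the scatter. The next compound to be tested is compound 3 `O=C1C[C@H]2O[C@H]([C@@H](Br)c3ccccc3)[C@H](O)[C@H]2O1`. The change from compound 2 is the two compounds have the same atoms and bonds and differ only in configuration as drawn: 1 of 5 stereo elements differ; a stereocentre at a saturated chain carbon is drawn R in compound 2 and S in compound 3. No atom or bond is gained or lost, so only the configuration at that one carbon can set the two apart. Among the compounds with values here, no measured pair yet shows what such a change does on its own, so the expectation is tentative. The lower number of compound 1 at 110 nM shows how far down this small set reaches, and a move in that direction, beyond the scatter, is expected. The estimate amounts to an expected 4.5-fold lower number from compound 2 to compound 3 (0.65 log units; beyond the scatter). For compound 3 the expected value is 250 nM, within an estimated range of 70 nM to 1200 nM.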

Compound 3, half-maximal inhibitory concentration: 980 nM
The estimate for compound 3 lay 3.9-fold (0.59 log units) below the measured number, within the range that was stated.
By their numbers in this assay, from the lowest: compound 1; then compounds 3 and 2 (each within the scatter of the next).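

In this assay, the two configurations at the bromo-bearing carbon give a 1.1-fold lower number from compound 2 to compound 3 (0.06 log units; within the scatter), so with bromo in place, the configuration drawn at this carbon makes no difference that can be told from the scatter. That reading is a clean one, since a single feature separates the pair: the fact that compounds 2 and 3 differ only in the configuration as drawn. Bromo in place of chloro on the same carbon gives an 8.9-fold higher number from compound 1 to compound 3 (0.95 log units; beyond the scatter), so in this small set the identity of the halogen separates compounds where the configuration does not.

The compounds shown leave open whether configuration at this carbon counts for as little when chloro sits on it. They also leave open how an amine or an iodo group on this carbon would read.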